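Urea-hydrazone series: from compound 3 to compound 4

The source may report more compounds than this note shows. Statements on the series, on what has been measured and on what is new or still open speak of the compounds shown alone.

Measured so far, in a functional assay on NCI-H460 cells (Homo sapiens) for cytotoxicity, read by MTT assay, with a stated time of 72 h; a lower number here means a stronger inhibitor, a higher number a weaker inhibitor:
compound 1 `CN(C)CCn1cnnc1-c1cc(Oc2ccc(NC(=O)N/N=C/c3ccc(O)c(O)c3)cc2F)ccn1` gives 1930 nM;
compound 2 `CN(C)CCn1cnnc1-c1cc(Oc2ccc(NC(=O)N/N=C/c3c[nH]c4ccccc34)cc2F)ccn1` gives 1630 nM;
compound 3 `COc1ccc(/C=N/NC(=O)Nc2ccc(Oc3ccnc(-c4nncn4CCN(C)C)c3)c(F)c2)cc1O` gives 620 nM.

Compound 3 holds the lowest number of the three. Its nearest neighbour is compound 2, and the gap is a 2.6-fold lower number from compound 2 to compound 3 (0.42 log units; beyond the scatter); the furthest is compound 1, with a 3.1-fold lower number from compound 1 to compound 3 (0.49 log units; beyond the scatter). Both gaps lie beyond the scatter, so compound 3 stands apart from the other two on this assay. Compound 1 and compound 2 sit close together, a 1.2-fold lower number from compound 1 to compound 2 (0.07 log units; within the scatter), and nothing separates them.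

Compound 4 `COc1cc(/C=N/NC(=O)Nc2ccc(Oc3ccnc(-c4nncn4CCN(C)C)c3)c(F)c2)cc(OC)c1OC` is the next step from compound 3. The change is 3,4,5-trimethoxyphenyl in place of 3-hydroxy-4-methoxyphenyl on a carbon with a double bond to nitrogen. For the measured compounds named here, two measured steps bear on it. The step from compound 1 to compound 3 is the closest analogy, since it also replaces a hydrogen on an oxygen with a methyl, and it was modest and beyond the scatter. The step from compound 2 to compound 3 swapped the whole aromatic ring and was of similar size. Neither step shows what a third methoxy adds, so no direction beyond the scatter is asserted with confidence; a small step to a lower number is the working expectation.

Compound 4 is therefore expected to give 450 nM, with a range from 150 nM to 1500 nM. This estimate means a step of a 1.4-fold lower number from compound 3 to compound 4 (0.14 log units; within the scatter), expected to fall within the scatter.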

Compound 4, half-maximal inhibitory concentration: 2770 nM
Compound 4: middle estimate off by 6.2-fold (0.79 log units), on the low side; the whole stated range lies below it.
By their numbers in this assay, from the lowest: compound 3; then compounds 2, 1 and 4 (each within the scatter of the next).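

In this assay, the step of a 4.5-fold higher number from compound 3 to compound 4 (0.65 log units; beyond the scatter) runs against the direction of the step of a 3.1-fold lower number from compound 1 to compound 3 (0.49 log units; beyond the scatter) and shows that more methoxy on this aromatic ring does not by itself go with a lower number. The steps of a 1.7-fold higher number from compound 2 to compound 4 (0.23 log units; within the scatter) and a 1.4-fold higher number from compound 1 to compound 4 (0.16 log units; within the scatter) place compound 4 level with compound 1 and compound 2, so 3,4,5-trimethoxyphenyl, 1H-indol-3-yl and 3,4-dihydroxyphenyl cannot be told apart on the carbon with a double bond to nitrogen, and of the four groups only the 3-hydroxy-4-methoxyphenyl of compound 3 stands apart. Nothing at hand gives a measured reason for the rise from compound 3 to compound 4.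

The change from compound 3 to compound 4 both replaces the hydroxy group and adds a methoxy group, and the compounds shown do not separate these two edits; a dimethoxyphenyl group would bear directly on that. Going by these compounds, it also stays open whether the low number of compound 3 needs a hydroxy group as such, or whether an amine or a carboxylic acid on the same ring would give a similar number.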